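The compounds below may be only part of what the source reports. "The series", "measured", "known", "first", "only" and "open" are said of these compounds alone.

Of the compounds shown here, three have a number so far. Compound 1 `N#C/C(=C\N1CCN(C(=O)c2ccco2)C1=S)C(N)=O`, in a functional assay on MT4 cells (Homo sapiens) for antiproliferative activity, read by MTT assay (on this read-out higher numbers stand for weaker inhibition and lower numbers for stronger inhibition), gives 4000 nM, the lowest of the three. Compound 2 `O=CN1CCN(C(=O)c2ccco2)C1=S` gives 9000 nM in this assay, and compound 3 `O=CN1CCN(c2ccc(Cl)c(Cl)c2)C1=S` gives 41000 nM. Both gaps from compound 1 are wider than the scatter of repeated measurements, so compound 1 stands as the most potent of the three in this assay, though the distance to compound 2 is the smaller of the two.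

Compound 4 `N#C/C(=C\N1CCN(C(=O)c2ccco2)C1=S)C(=O)c1ccccc1` has not yet been measured. It differs from compound 1 in one place: phenyl in place of amino on a carbonyl carbon. The same change, viewed one bond further out, reads carbamoyl to benzoyl.

Within the data shown here, no measured pair in this set shows this change, so the direction of the step has to be guessed. The change is expected to produce a small step in this assay, with a mild worsening somewhat more likely than an improvement, as nothing in the measured compounds points either way. Compound 4 is therefore expected to give 6000 nM, within a range from 1500 nM to 25000 nM. This corresponds to an expected step of a 1.5-fold higher number from compound 1 to compound 4 (0.18 log units; within the scatter).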

Compound 4, half-maximal inhibitory concentration: 3000 nM
The estimate for compound 4 lay 2.0-fold (0.30 log units) above the measured number, and the stated range covers the measured number.
By their numbers in this assay, from the lowest: compounds 4 and 1 (each within the scatter of the next); then compound 2; then compound 3.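

In this assay, phenyl in place of amino on a carbonyl carbon gives a 1.3-fold lower number from compound 1 to compound 4 (0.12 log units; within the scatter), so the two compounds cannot be told apart on this read-out. At this position, then, a small amino group with its hydrogen-bond donor and a phenyl ring with no such donor leave the number within the scatter, which shows that, for this pair, neither the donor nor the absence of a ring is required to keep the number where compound 1 has it. No measured property of these groups bears on this result, so the data offer no explanation for it.

This single step leaves open how far the position stays this permissive: a carboxylic acid, a methoxy group or a short alkyl chain on the same carbonyl carbon could behave differently, as could a phenyl ring carrying chlorine. It also leaves open whether the same change would give a comparable step on a core other than that of compound 1, or in any read-out other than this assay.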